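The compounds below may be only part of what the source reports. "The series", "measured", "known", "first", "only" and "open" are said of these compounds alone.

Measured so far in an ADME assay on HCT-116 cells (Homo sapiens) for cytotoxicity, read by CellTiter-Glo, with a stated time of 72 h; on this read-out higher numbers stand for weaker inhibition and lower numbers for stronger inhibition:
compound 1 `CCc1ccc(S(=O)(=O)N2CCC(N3CCC(C)CC3)CC2)cc1` gives > 5000 nM, a limit of the assay.
compound 2 `CC1CCN(C2CCN(S(=O)(=O)c3cccc(-c4ccc(Cl)cc4)c3)CC2)CC1` gives > 5000 nM, a limit of the assay.
compound 3 `CC1CCN(C2CCN(C(=O)c3ccc(OC(F)(F)F)cc3)CC2)CC1` gives > 5000 nM, a limit of the assay.

Compound 1 stands only at a limit in this assay; no number is known for it, and the three measured compounds share one standing: the limit of > 5000 nM in this assay, at which 3 of the 3 values shown sit.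

Compound 4 `CC1CCN(C2CCN(S(=O)(=O)c3ccc(C#N)cc3)CC2)CC1` differs from compound 1 in one place: cyano in place of ethyl on an aromatic carbon. Within the data shown here, no step between measured compounds is available, so the size of this change in this assay cannot be read from the set; with every measured value at the limit, no shift beyond the scatter is expected in either direction. Compound 4 is expected to come out near 7000 nM, between 2500 nM and 25000 nM, most probably again as a limit. The expected step that the limit leaves unreadable from compound 1 to compound 4 is none beyond the scatter.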

Compound 4, half-maximal inhibitory concentration: > 5000 nM
Compound 4: only a limit was reported; the forecaster's own chance of this, stated with the estimate: 80%; the middle value is on the limit's open side.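

In this assay no step can be read from compound 1 to compound 4, because both values are limits: the limit of > 5000 nM in this assay, at which 4 of the 4 values shown sit 

The compounds shown leave open whether any change on the shared core gives a measured number rather than a limit.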